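The source may hold more compounds than are shown below. What is called first, only, known or untested is meant among the compounds shown, and "the series" means these compounds.

Measured so far:
- Compound 1, `CNC(=O)c1ccc(Oc2cccc(NC(=S)Nc3ccc(F)cc3)c2)nc1`: 32700 nM
- Compound 2, `CNC(=O)c1ccc(Oc2cccc(NC(=S)Nc3cc(C(F)(F)F)cc(C(F)(F)F)c3)c2)nc1`: 5860 nM

Both compounds share one core and differ only in the groups on the outer aromatic ring of the thiourea. In a functional assay on PC-3 cells (Homo sapiens) for antiproliferative activity, read by MTT assay (a lower number here means a stronger inhibitor, a higher number a weaker inhibitor), compound 1 gives 32700 nM, while compound 2 gives 5860 nM, the lower of the two numbers and a gap well beyond the scatter of this assay.

Compound 3, `CNC(=O)c1ccc(Oc2cccc(NC(=S)Nc3cccc(C(F)(F)F)c3)c2)nc1`, has not yet been measured. It differs from compound 2 in one place: hydrogen in place of trifluoromethyl on an aromatic carbon. One of the two trifluoromethyl groups is thus lost, leaving a single trifluoromethyl on that ring.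

For the measured compounds named here, with only two measured compounds, no step of this exact kind has been seen. Compound 3 is expected to land between compound 1 and compound 2, with a step of a 2.0-fold higher number from compound 2 to compound 3 (0.31 log units; beyond the scatter) toward a higher number, somewhat beyond the scatter. The estimate for compound 3 is 12000 nM, in the range 4000 nM to 35000 nM.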

Compound 3, half-maximal inhibitory concentration: 15400 nM
For compound 3 the middle estimate is 1.3-fold (0.11 log units) below the measured one; measured number inside the range.
By their numbers in this assay, from the lowest: compound 2; then compound 3; then compound 1.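

In this assay, taking away one of the two trifluoromethyl groups gives a 2.6-fold higher number from compound 2 to compound 3 (0.42 log units; beyond the scatter), so the second trifluoromethyl on this aromatic ring contributes a modest but real part of the activity of compound 2. A single trifluoromethyl still retains some advantage: 3-(trifluoromethyl)phenyl in place of 4-fluorophenyl gives a 2.1-fold lower number from compound 1 to compound 3 (0.33 log units; beyond the scatter), another modest step that places compound 3 in an intermediate position. No measurement of any other kind is available to explain either step.

The compounds shown leave open whether this trend depends on trifluoromethyl itself or would also hold for other groups on that aromatic carbon. As far as these compounds go, how a chlorine atom, a nitrile or a methoxy group would compare there remains unknown.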